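This account rests on a few compounds, and the source may have more. Where it says the series, first, only, none or still open, it means among the compounds named here.

Of the compounds shown here, three that share one core have so far been tested in a functional assay on HEK293 cells for antagonist activity at transient receptor potential cation channel subfamily V member 1 (Rattus norvegicus); on this read-out higher numbers stand for weaker inhibition and lower numbers for stronger inhibition. Compound 1 `CC(C)c1ccc(NC(=O)N2CCN(c3ncccc3[N+](=O)[O-])CC2)cc1` gives 190 nM. Compound 2 `CC(C)c1ccc(NC(=O)N2CCN(c3ncccc3Cl)CC2)cc1` gives 11.5 nM, and compound 3 `Cc1cccnc1N1CCN(C(=O)Nc2ccc(C(C)C)cc2)CC1` gives 25.3 nM. All three differ only in one group on an aromatic carbon of the shared core: the step of a 17-fold lower number from compound 1 to compound 2 (1.22 log units; beyond the scatter) is large, the step of a 7.5-fold lower number from compound 1 to compound 3 (0.88 log units; beyond the scatter) is modest, and the step of a 2.2-fold higher number from compound 2 to compound 3 (0.34 log units; beyond the scatter) is modest. On these numbers compound 2 stands lowest of the three, so it is the strongest inhibitor among them, with compound 3 nearest and compound 1 furthest away.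

Compound 4 `CCCCc1ccc(NC(=O)N2CCN(c3ncccc3Cl)CC2)cc1` is the next compound to be measured. It differs from compound 2 in one place: butyl in place of isopropyl on an aromatic carbon. None of the three measured steps touches this part of the molecule; each of them alters a group on a different ring of the shared core. Going by the values given here, there is therefore no measured precedent for this change, and the working expectation is that the number for compound 4 will not move beyond the usual scatter from that of compound 2, in either direction. Compound 4 is accordingly expected to give about 15 nM, within a range of 5 nM to 50 nM. This estimate corresponds to an expected step of a 1.3-fold higher number from compound 2 to compound 4 (0.12 log units; within the scatter).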

Compound 4, half-maximal inhibitory concentration: 117 nM
Compound 4: the middle estimate sits 7.8-fold (0.89 log units) below what was measured; the measured number lies above the stated range.
By their numbers in this assay, from the lowest: compound 2; then compound 3; then compounds 4 and 1 (each within the scatter of the next).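

Going by these compounds alone, this is the first measured change on the six-membered aromatic ring of carbon only, at the place para to a large group, and in this assay it gives a 10-fold higher number from compound 2 to compound 4 (1.01 log units; beyond the scatter), so inhibition falls markedly. The change itself is small on paper: butyl, with 4 heavy atoms, replaces isopropyl, with 3, and neither group has a ring, a hydrogen-bond donor or acceptor, or a net charge, yet this step counts as large, like a 17-fold lower number from compound 1 to compound 2 (1.22 log units; beyond the scatter), so this position is far from indifferent to a modest change in an alkyl group. No measurement at hand accounts for the size of this step.

Still open, going by these compounds, is whether the loss follows from the longer chain or from a straight chain replacing a branched one, a question that propyl or tert-butyl at this place would help to separate. Also open, on these data alone, is whether butyl has a similar effect when the chloro group of compound 4 is replaced by the methyl group found in compound 3.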